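This account rests on a few compounds, and the source may have more. Where it says the series, first, only, none or still open, it means among the compounds named here.

Measured so far:
compound 1 `COC(C)(C)CCCC(C)C/C=C/C(C)=C/C(=O)OC1CCCC1`: 7.01
compound 2 `C=CCNC(=O)/C=C(C)/C=C/CC(C)CCCC(C)C`: 5.23
compound 3 `CC(/C=C/CC(C)CCCC(C)C)=C\C(=O)c1ccccc1`: 7.26

In a physicochemical assay for lipophilicity (on this read-out lower numbers stand for lower lipophilicity and higher numbers for higher lipophilicity), compound 1 sits second highest of the three; compound 3 lies within the scatter of it, while compound 2 lies well below. For the measured compounds named here, the only step with both ends measured is a number 2.03 log units higher from compound 2 to compound 3 (beyond the scatter), a change on the carbonyl carbon, yet a different one from that now considered. Compound 4 `COC(C)(C)CCCC(C)C/C=C/C(C)=C/C(=O)CC(C)C` differs from compound 1 by isobutyl in place of cyclopentyloxy on a carbonyl carbon. Going by the values given here, no measured pair shows this change; the loss of two heavy atoms and of the hydrogen-bond acceptor suggests a moderate drop in this assay. For compound 4 the expected step is a number 0.71 log units lower from compound 1 to compound 4 (beyond the scatter), and compound 4 is estimated at 6.3, between 5.8 and 6.8.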

Compound 4, partition coefficient: 6.02
For compound 4 the middle estimate is 0.28 log units above the measured one; measured number inside the range.
By their numbers in this assay, from the lowest: compound 2; then compound 4; then compounds 1 and 3 (each within the scatter of the next).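

On a carbonyl carbon of the core of compound 1, a change that takes out the cyclopentyloxy ring and its hydrogen-bond acceptor moves the number beyond the scatter in this assay: a number 0.99 log units lower from compound 1 to compound 4 (beyond the scatter). This position therefore responds to a swap between two groups without a donor, not only to the phenyl and allylamino swap of a number 2.03 log units higher from compound 2 to compound 3 (beyond the scatter). No supporting evidence on the origin of this step is available.

Still open, as far as these compounds go, is whether the ring or the oxygen accounts for the step, and how a dimethylamino group or a longer chain on this carbonyl carbon would read in this assay.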